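The compounds below may be only part of what the source reports. "The series", "measured", "known", "first", "only" and "open" are said of these compounds alone.

Working notes on the series.

The shared core is carried by compound 1 `Cc1ccc(S(=O)(=O)c2nc3ccccc3nc2Nc2ccccc2)cc1`. In a functional assay on A549 cells (Homo sapiens) for cytotoxicity, read by MTT assay, with a stated time of 72 h (on this read-out lower numbers stand for stronger inhibition and higher numbers for weaker inhibition), compound 1 gives 12500 nM. Compound 2 `COc1ccc(Nc2nc3ccccc3nc2S(=O)(=O)c2ccc(C)cc2)cc1` differs by methoxy in place of hydrogen on an aromatic carbon. In this assay compound 2 gives only a limit, > 50000 nM. The step is an at least 4.0-fold higher number from compound 1 to compound 2 (0.60 log units; beyond the scatter), and its size is bounded by the limit of > 50000 nM in this assay, at which 1 of the 3 values shown sits. Compound 3 `COc1cc(Nc2nc3ccccc3nc2S(=O)(=O)c2ccc(C)cc2)cc(OC)c1` differs from compound 1 by 3,5-dimethoxyphenyl in place of phenyl on a nitrogen on an aromatic ring. In this assay compound 3 gives 8060 nM, a step of a 1.6-fold lower number from compound 1 to compound 3 (0.19 log units; within the scatter), so these two values cannot be ordered. From the limit of compound 2 the step to compound 3 is an at least 6.2-fold lower number from compound 2 to compound 3 (0.79 log units; beyond the scatter).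

Compound 4 `COc1cc(Nc2nc3ccccc3nc2S(=O)(=O)c2ccc(C)cc2)cc(OC)c1OC` is not yet measured. It differs from compound 3 by methoxy in place of hydrogen on an aromatic carbon. This is the same kind of change as methoxy in place of hydrogen on an aromatic carbon, but the surroundings differ: in compound 4 the entering methoxy is ortho to two methoxy groups (2 heavy atoms each) and para to a large group, whereas in compound 2 it is only para to a large group. The cores also differ, by 3,5-dimethoxyphenyl in place of phenyl on a nitrogen on an aromatic ring.

Beside the measured step of an at least 4.0-fold higher number from compound 1 to compound 2 (0.60 log units; beyond the scatter), the expected step for the new compound is a 2.5-fold higher number from compound 3 to compound 4 (0.39 log units; beyond the scatter); this rests on the worsening seen from compound 1 to compound 2 in this assay, tempered by the changed surroundings, which the data do not resolve. Compound 4 is therefore estimated at 20000 nM in this assay, expected to lie between 5000 nM and 60000 nM, with a real chance that only a limit is reported.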

Compound 4, half-maximal inhibitory concentration: 5610 nM
Beside the measured number, compound 4's estimate is 3.6-fold (0.55 log units) above it; measured number inside the range.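

In this assay, methoxy in place of hydrogen on an aromatic carbon gives a 1.4-fold lower number from compound 3 to compound 4 (0.16 log units; within the scatter), so these two values cannot be ordered and the change shows no measurable effect on this core. The change therefore does not carry over in size from the core of compound 1 to that of compound 3, and the worsening seen on the first core cannot be assumed on the second: the same change on two cores in this assay, an at least 4.0-fold higher number (0.60 log units; beyond the scatter) from compound 1 to compound 2 and a 1.4-fold lower number (0.16 log units; within the scatter) from compound 3 to compound 4, at least 5.7-fold (0.75 log units) apart, beyond the scatter of two such steps. This does not show whether the difference follows from the 3,5-dimethoxyphenyl core or from the surroundings of the entering methoxy, which is ortho to two methoxy groups only in compound 4, and the size of the gap is only a bound, as compound 2 is known only as a limit: the limit of > 50000 nM in this assay, at which 1 of the 4 values shown sits.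

The compounds shown leave open whether the same place on the ring of compound 4 tolerates a group other than methoxy, such as an amine, a carboxylic acid or a longer alkoxy chain. They also leave open whether methoxy at another place on the phenyl of compound 1 would behave as in compound 2 or as in compound 4.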